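The compounds below may be only part of what the source reports. "The series", "measured", "known", "first", "only" and "open" are said of these compounds alone.

Compound 3 `CS(=O)(=O)CCc1c(Cn2c(=O)n(C3CC3)c3ccncc32)nc2cc(Cl)ccn12` stands in an ADME assay on HEp-2 cells (Homo sapiens) for cytotoxicity, read by CCK-8 assay, with a stated time of 6 days (a lower number here means that less compound is tolerated, a higher number that more compound is tolerated), at the edge of what the assay reports: compound 3 gives > 100000 nM, which is a limit of the assay and not a number. Compound 1 `O=c1n(Cc2nc3cc(Cl)ccn3c2CO)c2cnccc2n1C1CC1` gives > 100000 nM, also a limit. Compound 2 `O=C(NCCO)c1c(Cn2c(=O)n(C3CC3)c3ccncc32)nc2cc(Cl)ccn12` gives > 100000 nM, again a limit. All three values sit at the limit of > 100000 nM in this assay, at which 3 of the 3 values shown sit, so the steps a step that the two limits leave unreadable from compound 1 to compound 2, a step that the two limits leave unreadable from compound 1 to compound 3 and a step that the two limits leave unreadable from compound 2 to compound 3 cannot be sized in either direction. Compound 4 `O=c1n(Cc2nc3cc(Cl)ccn3c2NC2CCCCC2)c2cnccc2n1C1CC1` differs from compound 3 by cyclohexylamino in place of 2-(methylsulfonyl)ethyl on an aromatic carbon. For the measured compounds named here, none of the measured steps touches a cyclohexylamino group or any nitrogen-linked substituent at that carbon, and all of them are unreadable, so they give no direction for this change; they show only that three different groups at this position each left the compound tolerated up to the limit. With that, compound 4 is expected to give about 70000 nM, within a range from 15000 nM to 200000 nM, and the step of an at least 1.4-fold lower number from compound 3 to compound 4 (0.15 log units; that floor lies within the scatter) is expected to stay within the usual scatter, though a reported number rather than a limit is possible.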

Compound 4, half-maximal cytotoxic concentration: > 100000 nM
Compound 4: only a limit was reported; the forecaster's own chance of this, stated with the estimate: 50%; middle value at least 1.4-fold (0.15 log units) away from the limit.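

In this assay compound 4 gives > 100000 nM as a limit of the assay and not a number. Its steps from compound 1, compound 2 and compound 3 therefore cannot be read: the limit of > 100000 nM in this assay, at which 4 of the 4 values shown sit. The compounds shown leave open whether these four differ at all in how much compound is tolerated.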